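Hydrazone aryl swap on a shared triazolopyrimidine-free core

This account rests on a few compounds, and the source may have more. Where it says the series, first, only, none or still open, it means among the compounds named here.

Measured compounds:
compound 1, `C#CCSc1nc(N/N=C/c2ccc(N(C)C)cc2)c2nnn(Cc3ccccc3)c2n1`, in a functional assay on MCF7 cells (Homo sapiens) for antiproliferative activity, read by MTT assay, with a stated time of 72 h; a lower number here means a stronger inhibitor, a higher number a weaker inhibitor: > 64000 nM
compound 2, `CCCSc1nc(N/N=C(\C)c2ccccc2O)c2nnn(Cc3ccccc3Cl)c2n1`, in this assay: > 64000 nM

Compound 1 gives only a limit in this assay, namely > 64000 nM. Compound 2 likewise gives only a limit in this assay, > 64000 nM. Compound 1 thus stands at the limit of > 64000 nM in this assay, at which 2 of the 2 values shown sit, and no number separates it from compound 2; nothing here ranks one against the other.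

Compound 3, `C#CCSc1nc(N/N=C/c2c(O)ccc3ccccc23)c2nnn(Cc3ccccc3)c2n1`, differs from compound 1 by 2-hydroxynaphthalen-1-yl in place of 4-(dimethylamino)phenyl on a carbon with a double bond to nitrogen. Going by the values given here, no measured step bears on this change, and the two measured values, both limits, give no direction to read from. With compound 1 at the limit, a step toward weaker inhibition could not be seen at all; only a move toward stronger inhibition, or none beyond the scatter, is observable. The step from compound 1 to compound 3 in this assay is expected to be an at least 1.8-fold lower number from compound 1 to compound 3 (0.26 log units; that floor lies within the scatter), a modest and uncertain gain. Compound 3 is therefore expected at 35000 nM in this assay, with a range from 6000 nM to 64000 nM, and a real chance that only a limit is reported again.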

Compound 3, half-maximal inhibitory concentration: 8970 nM
Beside the measured number, compound 3's estimate is 3.9-fold (0.59 log units) above it; the range from low to high includes it.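

Going by these compounds alone, with 2-hydroxynaphthalen-1-yl in place of 4-(dimethylamino)phenyl on a carbon with a double bond to nitrogen, this assay shows an at least 7.1-fold lower number from compound 1 to compound 3 (0.85 log units; beyond the scatter), and this is the first readable step. It shows that a change at this one place can move the result beyond the scatter, and compound 3, at 8970 nM, gives the only true number among the three compounds shown. Compound 1 and compound 2 had offered only a limit and no number: the limit of > 64000 nM in this assay, at which 2 of the 3 values shown sit.

The step swaps the whole aryl group at once, adding a second aromatic ring and a hydroxyl and removing the dimethylamino group, so the compounds shown do not tell which of these carries the gain; a naphthalen-1-yl group without the hydroxyl, or a 2-methoxynaphthalen-1-yl group, on the same carbon would begin to separate them. As far as these compounds go, how large the step really is also stays open, as does whether the same group would give a number on a core carrying the other substituents of compound 2.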